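Further methoxy on the shared core of compound 1

The source may hold more compounds than are shown below. What is called first, only, known or untested is meant among the compounds shown, and "the series" means these compounds.

Among the compounds with values here, compound 1 `COc1ccc(C(=O)/C=C/c2cc(-c3cc(OC)c(OC)c(OC)c3)n[nH]2)cc1OC` gives 92% in a functional assay on Malme-3M cells (Homo sapiens) for cytotoxicity, read by sulforhodamine B assay, with a stated time of 48 h, tested at 0.1 uM (a higher number here means a weaker effect of the compound at the concentration tested, a lower number a stronger effect), the highest of the two numbers so far; compound 2 `COc1ccc(C(=O)/C=C/c2cc(-c3cc(OC)c(OC)c(OC)c3)n[nH]2)cc1` gives 91%, within the scatter of compound 1. Within the data shown here, the only step available, a number 1 percentage points lower from compound 1 to compound 2 (within the scatter), came from hydrogen in place of methoxy on an aromatic carbon. Compound 3 `COc1cc(C(=O)/C=C/c2cc(-c3cc(OC)c(OC)c(OC)c3)n[nH]2)cc(OC)c1OC` differs from compound 1 by methoxy in place of hydrogen on an aromatic carbon. That measured step runs in the opposite sense to this change and stayed within the scatter, so no step beyond the scatter is expected in this assay. For compound 3 the estimate is 92%, range 80% to 100%, an expected step of no change at the digits printed from compound 1 to compound 3 (within the scatter).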

Compound 3, a percentage reported as activity, at one concentration (the size of the read-out at that concentration, not a potency): 101%
Compound 3: middle estimate off by 9 percentage points, on the low side, and the stated range ends below it.
By their numbers in this assay, from the lowest: compounds 2, 1 and 3 (each within the scatter of the next).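

Methoxy in place of hydrogen at this position, ortho to a methoxy group and meta to a large group, gives a number 9 percentage points higher from compound 1 to compound 3 (within the scatter) in this assay at the concentration tested. With the removal of a methoxy in compound 2 also within the scatter of compound 1, neither single change on this ring shows a measurable effect here. No measurement bearing on the reason is available.

Open, on these data alone, is whether another group at this position, such as an amine or a carboxylic acid, would give a step beyond the scatter. A single concentration also gives no potency for any of these compounds.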